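This account rests on a few compounds, and the source may have more. Where it says the series, first, only, none or still open, it means among the compounds named here.

Compound 2 `CN(C)c1cccc(Oc2ccc3c(NCCCNCc4ccco4)ccnc3c2)c1` stands level with compound 1 `COc1cccc(Oc2ccc3c(NCCCNCc4ccco4)ccnc3c2)c1` in a physicochemical assay for solubility, with a stated time of 18 h, at pH 7.4; on this read-out higher numbers stand for higher solubility and lower numbers for lower solubility: compound 1 gives 14500 nM and compound 2 gives 14500 nM. The next structure is compound 3 `CC(C)CCc1ccc2c(NCCCNCc3ccco3)ccnc2c1`, with isopentyl in place of 3-(dimethylamino)phenoxy on an aromatic carbon of the shared core: isopentyl in place of 3-(dimethylamino)phenoxy on an aromatic carbon. For the measured compounds named here, only one measured step bears on this, no change at the digits printed from compound 1 to compound 2 (within the scatter), with dimethylamino in place of methoxy, and it stays within the scatter. That step alters only one substituent of the aryl ether, whereas here the whole 3-(dimethylamino)phenoxy group goes. Going by the values given here, the data therefore hold no direct precedent and give no direction, so no step beyond the scatter is expected in this assay, with wide uncertainty. The estimated step is a 1.2-fold higher number from compound 2 to compound 3 (0.09 log units; within the scatter). For compound 3 the expected value is 18000 nM, with an estimated range of 6000 nM to 50000 nM.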

Compound 3, solubility: 4200 nM
For compound 3 the middle estimate is 4.3-fold (0.63 log units) above the measured one; measured number outside the range, below it.
By their numbers in this assay, from the lowest: compound 3; then compounds 1 and 2 (each within the scatter of the next).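

In this assay the read-out responds to the group on this aromatic carbon: there is a 3.5-fold lower number from compound 2 to compound 3 (0.54 log units; beyond the scatter) with isopentyl in place of 3-(dimethylamino)phenoxy, and a 3.5-fold lower number from compound 1 to compound 3 (0.54 log units; beyond the scatter) with isopentyl in place of 3-methoxyphenoxy. For the compounds shown here, the only earlier step changed a substituent on the aryl ether and stayed within the scatter, whereas these are the first steps beyond it, and both remove the whole aryl ether. Nothing at hand indicates what underlies these steps.

Because the oxygen link and the aromatic ring leave together, the compounds shown do not separate them; a phenyl group bonded directly to this carbon, or an isopentyloxy chain, would do so. On these data alone, how a chain ending in an amine or a carboxylic acid would read at this position also stays open.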